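The compounds below may be only part of what the source reports. "The series", "measured", "known", "first", "only" and "open" are said of these compounds alone.

Measured compounds:
compound 1, `Brc1ccc(-c2cc3ccccc3[nH]2)cc1`: 4.8%
compound 2, `CCCCCc1ccc(-c2cc3ccccc3[nH]2)cc1`: 0%

In an assay on isolated protein for inhibition of Aromatase (Homo sapiens), read by fluorescence, using NADPH, with a stated time of 30 min, tested at 50 uM (a higher number here means more inhibition at the concentration tested (going by the name of the read-out), a lower number less inhibition), compound 2 gives 0%, the lowest of the two numbers recorded; its nearest neighbour is compound 1, and the step of a number 4.8 percentage points lower from compound 1 to compound 2 (within the scatter) lies within the scatter, so the two compounds cannot be ranked against each other on these numbers. Compound 3, `FC(F)(F)Oc1ccc(-c2cc3ccccc3[nH]2)cc1`, is the next compound to be tested in this assay. Its difference from compound 2 is trifluoromethoxy in place of pentyl on an aromatic carbon. Within the data shown here, the only measured step that bears on this change is the one from compound 1 to compound 2, where a bromo group gave way to a pentyl chain at the same position and the result was a number 4.8 percentage points lower from compound 1 to compound 2 (within the scatter), not beyond the scatter. Among the measured compounds shown here, both measured compounds sit near the bottom of the percentage scale, and the one exchange at this position did nothing measurable. On that basis the expected step of a number 3 percentage points higher from compound 2 to compound 3 (within the scatter) is none beyond the scatter. Compound 3 is therefore estimated to give 3% in this assay, expected to fall between 0% and 15%.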

Compound 3, a percentage reported as inhibition, at one concentration (the size of the read-out at that concentration, not a potency): 1.86%
For compound 3 the middle estimate is 1.1 percentage points above the measured one; the range from low to high includes it.
By their numbers in this assay, from the lowest: compounds 2, 3 and 1 (each within the scatter of the next).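

In this assay, replacing pentyl with trifluoromethoxy gives a number 1.9 percentage points higher from compound 2 to compound 3 (within the scatter), and replacing bromo with trifluoromethoxy gives a number 2.9 percentage points lower from compound 1 to compound 3 (within the scatter). The earlier compounds shown here offered a single exchange at this position; there are now three groups to compare, and no pair among them separates on these numbers, even though trifluoromethoxy brings oxygen, fluorine and a hydrogen-bond acceptor in place of the all-carbon pentyl, which has none. No evidence is at hand on what lies behind these readings.

From the compounds shown here alone, all three groups leave the reading at the low end of the percentage scale, so it remains open whether any group at this position can lift it clear of the others, for instance an amine, a carboxylic acid or a hydroxyl group. Going by these compounds, it also remains open whether a change elsewhere on the shared core would do what these exchanges at this position have not.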